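This account rests on a few compounds, and the source may have more. Where it says the series, first, only, none or still open, it means among the compounds named here.

For the measured compounds named here, compound 1, `CN1CCCN(CCn2ccc3ccc(Br)cc32)CC1`, is one of two compounds measured so far in an assay on HEK293 cells for binding affinity to 5-hydroxytryptamine receptor 7 (Homo sapiens), read by radioligand binding, tested at 1 uM; a lower number here means less inhibition, a higher number more inhibition at the concentration tested (going by the name of the read-out). In this assay compound 1 gives 93%, the higher of the two numbers. The other measured compound, compound 2, `Brc1ccc2ccn(CCN3CCC4CCCCN4CC3)c2c1`, gives 71% in this assay, and the gap between the two lies beyond the usual scatter of repeated measurements. Compound 2 differs from compound 1 in more than one place, so those two numbers say nothing about what any single change does.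

Compound 3, `CN1CCCN(CCn2ccc3ccc(C(F)(F)F)cc32)CC1`, has not yet been measured. It differs from compound 1 in one place: trifluoromethyl in place of bromo on an aromatic carbon. Going by the values given here, no single-change step between measured compounds is available, so the size of the step in this assay is uncertain. The step expected in this assay is a number 8 percentage points lower from compound 1 to compound 3 (within the scatter), either within the scatter or a modest decrease. Compound 3 is estimated to give 85%, with a range from 62% to 97%.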

Compound 3, a percentage reported as inhibition, at one concentration (the size of the read-out at that concentration, not a potency): 89%
Compound 3: the middle estimate sits 4 percentage points below what was measured; measured number inside the range.
By their numbers in this assay, from the lowest: compound 2; then compounds 3 and 1 (each within the scatter of the next).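

For the compounds shown here, this is the first single-change step available in this assay: trifluoromethyl in place of bromo on this aromatic carbon gives a number 4 percentage points lower from compound 1 to compound 3 (within the scatter). At this position, then, a group of 1 heavy atom can be replaced by one of 4 heavy atoms with no change beyond the scatter, although a single test concentration gives a size of effect and not a potency. No supporting measurement bears on why the two groups read alike.

The compounds shown leave open whether other groups on this carbon, such as chloro, methoxy or a nitrile, would also leave the number within the scatter. They also leave open whether the same swap would give a similar step on the amine portion of compound 2.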